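Cytotoxicity notes: chloro in place of nitro

A few compounds are considered here, and "the series" means these few. Any claim that something is new, unique, unknown or untested is made for them only; others in the source may bear on it.

Measured so far:
Compound 1 `O=[N+]([O-])c1cccc(/N=N/N2CCCCC2)c1` in an ADME assay on MT4 cells (Homo sapiens) for cytotoxicity, read by MTT assay, with a stated time of 96 h; on this read-out lower numbers stand for higher toxicity in this test and higher numbers for lower toxicity in this test: > 100000 nM; this is a limit of the measurement, not a number.
Compound 2 `O=[N+]([O-])c1ccc(/N=N/N2CCCC2)cc1` in this assay: >= 100000 nM; this too is a limit of the measurement.

Within the data shown here, compound 2 therefore stands at a limit in this assay, and the one further value shown, for compound 1, is a limit as well (the limit of > 100000 nM in this assay, at which 1 of the 2 values shown sits; (the limit of >= 100000 nM in this assay, at which 1 of the 2 values shown sits)). Neither value is a number, so no step between measured compounds can be sized, and nothing in the shown values separates compound 1 from compound 2.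

The next compound, compound 3 `Clc1ccc(/N=N/N2CCCC2)cc1`, differs from compound 2 in one place: chloro in place of nitro on an aromatic carbon.

Among the measured compounds shown here, with both measured compounds sitting at limits in this assay, there is no measured step to lean on. The step of a number no higher from compound 2 to compound 3 (the limit leaves the size open) is expected to be none beyond the scatter. Compound 3 is expected to give about 100000 nM in this assay, in the range 30000 nM to 300000 nM, and it is expected that the assay may again report only a limit rather than a number.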

Compound 3, half-maximal cytotoxic concentration: > 100000 nM
Compound 3: no number, only a limit (the forecaster's own chance of this, stated with the estimate: 65%); the middle value sits exactly at the limit.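

No step can be read from compound 2 to compound 3: both results in this assay are limits of the measurement, not numbers, so the effect of chloro in place of nitro cannot be sized. The compounds shown leave open whether chloro and nitro differ at all on this read-out, since none of them has a numerical value.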